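This account rests on a few compounds, and the source may have more. Where it says the series, first, only, none or still open, it means among the compounds named here.

Working notes on a small set of diaminotriazines varied at the ring nitrogen substituent. Compound 1 `NC1=NC2(CCCCC2)N(c2ccc(Cl)cc2)C(N)=N1` is reported only as a limit of the assay: in an assay for inhibition of Dihydrofolate reductase (Bos taurus), using NADPH (on this read-out lower numbers stand for stronger inhibition and higher numbers for weaker inhibition), compound 1 gives > 100000 nM. Compound 2 `COc1ccc(N2C(N)=NC(N)=NC23CCCCC3)cc1` is likewise reported only as a limit: in this assay compound 2 gives > 100000 nM. The step that the two limits leave unreadable from compound 1 to compound 2 cannot be read, since both ends rest on (the limit of > 100000 nM in this assay, at which 2 of the 3 values shown sit). Among the compounds with values here, compound 3 `CC1(C)N=C(N)N=C(N)N1Cc1ccccc1` is the only compound with a number rather than a limit. In this assay compound 3 gives 19500 nM.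

Compound 4 `COc1ccc(CN2C(N)=NC(N)=NC2(C)C)cc1` has not yet been measured and differs from compound 3 by methoxy in place of hydrogen on an aromatic carbon. Within the data shown here, no measured step makes the same change: the only measured step, a step that the two limits leave unreadable from compound 1 to compound 2, exchanges methoxy for chloro rather than for hydrogen, and it is unreadable between two limits. Nothing measured therefore bears on the size or direction of this change. The expectation for compound 4 is accordingly a step of a 1.3-fold higher number from compound 3 to compound 4 (0.11 log units; within the scatter) within the usual scatter, in no firm direction, and with a wide range. Compound 4 is estimated at 25000 nM, expected to lie between 8000 nM and 80000 nM.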

Compound 4, half-maximal inhibitory concentration: 58800 nM
Beside the measured number, compound 4's estimate is 2.4-fold (0.37 log units) below it, within the range that was stated.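

This gives the series its first readable step on the aromatic ring: hydrogen gives way to methoxy, para to a large group, and this produces a 3.0-fold higher number from compound 3 to compound 4 (0.48 log units; beyond the scatter) in this assay. On this read-out the higher number stands for weaker inhibition, so the added methoxy is accommodated at this place with a modest loss that lies beyond the usual scatter, and the change is not neutral. The earlier pair could not show this, since the exchange of chloro for methoxy between compound 1 and compound 2 cannot be read: the limit of > 100000 nM in this assay, at which 2 of the 4 values shown sit.

Whether the loss belongs to methoxy itself or would come with any group at this place remains open, since the core of compound 3 is shown here with only hydrogen and methoxy on its aromatic ring; a hydroxyl, an amine or a fluorine at the same carbon would help separate these cases. Also open, going by these compounds, is whether a longer chain such as ethoxy would take the number further in the same direction or bring it back.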